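The source may hold more compounds than are shown below. What is called first, only, known or untested is meant among the compounds shown, and "the series" means these compounds.

Among the measured compounds shown here, compound 1 `COCOc1cc(C2=C(c3cc(OC)c(OC)c(OC)c3)C(=O)CC2O[SiH2]C(C)(C)C)ccc1OC` is the only member of this small set that returns a number in an ADME assay on PA-1 cells (Homo sapiens) for cytotoxicity, read by MTT assay, with a stated time of 72 h; on this read-out higher numbers stand for weaker inhibition and lower numbers for stronger inhibition: compound 1 gives 13.5 ug/mL. Compound 2 `COc1ccc(C2=C(c3cc(OC)c(OC)c(OC)c3)C(=O)CC2C)cc1C(=O)O` is reported only as a limit of the assay, > 100 ug/mL, with no number behind it; this is the case described by the limit of > 100 ug/mL in this assay, at which 1 of the 2 values shown sits. For the measured compounds named here, no step between two measured compounds is available, so nothing measured says how a change on the aryl group shifts this read-out.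

Compound 3 `COc1cc(C2=C(c3cc(C)c(OC)c(C)c3)C(O[SiH2]C(C)(C)C)CC2=O)cc(OC)c1OC` differs from compound 1 in one place: 4-methoxy-3,5-dimethylphenyl in place of 4-methoxy-3-(methoxymethoxy)phenyl on a double-bonded ring carbon. Going by the values given here, with no measured step to lean on, the account expects the change from compound 1 to compound 3 to stay within the ordinary scatter of this assay, a 1.5-fold higher number from compound 1 to compound 3 (0.17 log units; within the scatter), perhaps drifting slightly toward weaker inhibition. Compound 3 is therefore estimated at 20 ug/mL in this assay, with a plausible range from 6 ug/mL to 60 ug/mL.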

Compound 3, half-maximal inhibitory concentration: 32 ug/mL
Beside the measured number, compound 3's estimate is 1.6-fold (0.20 log units) below it; measured number inside the range.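

In this assay, the aryl group on the double-bonded ring carbon now has its first measured step: 4-methoxy-3,5-dimethylphenyl in place of 4-methoxy-3-(methoxymethoxy)phenyl gives a 2.4-fold higher number from compound 1 to compound 3 (0.37 log units; beyond the scatter). This shows that the read-out responds to the aryl group at this position, moving toward weaker inhibition, while compound 3 still returns a number rather than a limit. The exchange alters more than one feature of the aryl group at once, so this single step cannot assign the shift to any one of them, and nothing measured here explains it.

The compounds shown leave open how an aryl group carrying a hydroxyl or an amine would read at this position, with the rest of the core of compound 1 unchanged. They also leave open whether the same exchange would shift the number by a similar amount on a different core.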